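Extending the Side Chain of Compound 3

The source may report more compounds than this note shows. Statements on the series, on what has been measured and on what is new or still open speak of the compounds shown alone.

In a functional assay on PC-3 cells (Homo sapiens) for antiproliferative activity, read by MTT assay, with a stated time of 72 h (on this read-out higher numbers stand for weaker inhibition and lower numbers for stronger inhibition), compound 1 `O=C(N/N=C/c1ccc(Cl)c(Cl)c1)Nc1ccc(Oc2ccnc3[nH]ccc23)c(F)c1` gives 14100 nM, compound 2 `O=C(N/N=C/c1ccc(O)c(Br)c1)Nc1ccc(Oc2ccnc3[nH]ccc23)c(F)c1` gives 28600 nM, and compound 3 `CN(C)CCn1cccc1/C=N/NC(=O)Nc1ccc(Oc2ccnc3[nH]ccc23)c(F)c1` gives 1600 nM, the lowest of the three numbers. Compound 4 `CCN(CC)CCCn1cccc1/C=N/NC(=O)Nc1ccc(Oc2ccnc3[nH]ccc23)c(F)c1` keeps the shared core but carries (diethylamino)methyl in place of dimethylamino on a saturated chain carbon, two bonds along the chain from an aromatic nitrogen, so 2-(dimethylamino)ethyl becomes 3-(diethylamino)propyl. Going by the values given here, no measured step alters this chain. The nearest evidence comes from swapping the whole group on the carbon with a double bond to nitrogen: an 8.8-fold lower number from compound 1 to compound 3 (0.95 log units; beyond the scatter) and an 18-fold lower number from compound 2 to compound 3 (1.25 log units; beyond the scatter), both beyond the scatter. The change here is narrower than those swaps, so the expected step is small, a 1.1-fold lower number from compound 3 to compound 4 (0.03 log units; within the scatter), and no shift beyond the scatter is foreseen. Compound 4 is estimated at 1500 nM, within a range of 500 nM to 4500 nM.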

Compound 4, half-maximal inhibitory concentration: 2950 nM
Beside the measured number, compound 4's estimate is 2.0-fold (0.29 log units) below it, and the stated range covers the measured number.
By their numbers in this assay, from the lowest: compounds 3 and 4 (each within the scatter of the next); then compound 1; then compound 2.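

In this assay the move from 2-(dimethylamino)ethyl to 3-(diethylamino)propyl gives a 1.8-fold higher number from compound 3 to compound 4 (0.27 log units; within the scatter) and is the first change shown that alters this chain alone. The earlier steps shown here replaced the whole group, whereas here a longer chain with a larger amine stays within the scatter of the shorter one. No measurement shown accounts for this result.

Chain length and the amine's substituents change together here, so their separate contributions cannot be told apart. A 3-(dimethylamino)propyl chain, a 2-(diethylamino)ethyl chain, or a carboxylic acid in place of the amine remains an open case.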